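The compounds below may be only part of what the source reports. "The series", "measured", "known", "first", "only" and "open" are said of these compounds alone.

Measured compounds:
- compound 1, `CC(C)S(=O)(=O)NC(=O)c1ccc(Nc2nc(NC3(c4ccc(Cl)cc4)CC3)nc(OCC(F)(F)F)n2)cc1`: 96%
- compound 2, `CC(C)C(=O)NCCS(=O)(=O)NC(=O)c1ccc(Nc2nc(NC3(c4ccc(Cl)cc4)CC3)nc(OCC(F)(F)F)n2)cc1`: 84%
- compound 3, `O=C(NS(=O)(=O)CCNC(=O)C1CC1)c1ccc(Nc2nc(NC3(c4ccc(Cl)cc4)CC3)nc(OCC(F)(F)F)n2)cc1`: "not active" (no number reported)

Of the compounds shown here, three sharing one core have been tested in an ADME assay on microsomes from liver (Rattus norvegicus) for metabolic stability, with a stated time of 10 min; a lower number here means that less of the compound is left, a higher number that more of the compound is left. Compound 1 gives 96% in this assay, and compound 2 gives 84%. Compound 3, in contrast, carries no number in this assay; it is reported there only as "not active" (no number reported), so where compound 3 stands relative to the other two cannot be said beyond that.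

Among the measured compounds shown here, the one measured step, a number 12 percentage points lower from compound 1 to compound 2 (beyond the scatter), concerns a change on the sulfonyl sulfur, not the carbonyl carbon that is altered in the present step. Compound 4, `COC(=O)NCCS(=O)(=O)NC(=O)c1ccc(Nc2nc(NC3(c4ccc(Cl)cc4)CC3)nc(OCC(F)(F)F)n2)cc1`, differs from compound 3 as follows: methoxy in place of cyclopropyl on a carbonyl carbon. For the measured compounds named here, no measured step bears directly on this change, and compound 3 itself has no number from which a step could be counted. The expectation for compound 4 in this assay therefore rests on compounds 1 and 2 alone, which both keep most of the compound over the stated time, with a widened range because the nearest neighbour, compound 3, is unquantified. Compound 4 is estimated at 85%, expected to fall between 65% and 98%.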

Compound 4, percent of the compound remaining: 100%
Estimate against measurement, compound 4: 15 percentage points below, outside the stated range (above it).
By their numbers in this assay, from the lowest: compound 2; then compounds 1 and 4 (each within the scatter of the next).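

In this assay, among the compounds shown here, exchanging isopropyl for methoxy on the carbonyl carbon gives a number 16 percentage points higher from compound 2 to compound 4 (beyond the scatter), which shows that the read-out responds to the group on this carbonyl carbon, something the earlier compounds, with their single measured step on the sulfonyl sulfur, could not show. The group on the sulfonyl sulfur now has two readings: 2-((isopropylcarbonyl)amino)ethyl in place of isopropyl gives a number 12 percentage points lower from compound 1 to compound 2 (beyond the scatter), whereas 2-((methoxycarbonyl)amino)ethyl in place of isopropyl gives a number 4 percentage points higher from compound 1 to compound 4 (within the scatter), so exchanging isopropyl for this larger group on the sulfur does not by itself carry a step beyond the scatter. Nothing at hand accounts for the difference between the methoxycarbonyl and isopropylcarbonyl groups in this setting.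

Going by these compounds, the change from cyclopropyl to methoxy itself cannot be read, as compound 3 is reported only as "not active" with no number, so the place of cyclopropyl among the groups on this carbonyl carbon remains unknown. On these data alone, it also remains open how an ethoxy group or a dimethylamino group on this carbonyl carbon, or a free amine in place of the whole (methoxycarbonyl)amino group, would stand in this assay relative to methoxy.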